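This account rests on a few compounds, and the source may have more. Where it says the series, first, only, none or still open, it means among the compounds named here.

Measured compounds and values:
- compound 1, `COc1cc(C)cc(-c2c(-c3ccnc(-c4ccc(C(C)=O)cc4)c3)cnn2CC#N)c1`: 88%
- compound 2, `Cc1cc(O)cc(-c2nn(CC#N)cc2-c2ccnc(-c3ccc(Oc4ccccc4)cc3)c2)c1`: 86%
- compound 3, `COc1cc(C)cc(-c2nn(CC#N)cc2-c2ccnc(-c3ccc(N(C)C)cc3)c2)c1`: 96%

All three were read in a functional assay on PC-3 cells (Homo sapiens) for cytotoxicity, read by sulforhodamine B assay, with a stated time of 48 h, tested at 0.01 uM; a lower number here means a stronger effect, a higher number a weaker effect of the compound at the concentration tested. Compound 3 gives 96%, compound 1 gives 88% and compound 2 gives 86%; the gaps from compound 3 to either of the other two fall within the usual scatter, so the three numbers cannot be told apart and no order among them is claimed. Within the data shown here, each compound carries a different group on the outer aromatic ring of the pyridine side, and no pair of measured compounds differs in only one place, so no single step has been measured in this assay .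

Compound 4, `Cc1cc(O)cc(-c2nn(CC#N)cc2-c2ccnc(-c3ccc(N(C)C)cc3)c2)c1`, is not yet measured. It differs from compound 3 by hydrogen in place of methyl on an oxygen on an aromatic ring. Compound 2 already carries the hydroxy form of this ring, and its number sits close to that of compound 3, so the methoxy-to-hydroxy exchange is not expected to move the read-out beyond the scatter. The step from compound 3 to compound 4 is estimated at a number 6 percentage points lower from compound 3 to compound 4 (within the scatter), a small decrease or none beyond the scatter. Compound 4 is therefore expected to give about 90%, within the range 78% to 100%.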

Compound 4, a percentage reported as activity, at one concentration (the size of the read-out at that concentration, not a potency): 92%
Compound 4: middle estimate off by 2 percentage points, on the low side; low and high end bracket the measured number.
By their numbers in this assay, from the lowest: compounds 2, 1, 4 and 3 (each within the scatter of the next).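

In this assay, the exchange of methoxy for hydroxy on an oxygen on an aromatic ring now has a measured step with the dimethylamino group held constant: a number 4 percentage points lower from compound 3 to compound 4 (within the scatter). The group on the other side of the molecule also has its first measured step, with the 3-hydroxy-5-methylphenyl group held constant, as dimethylamino in place of phenoxy on an aromatic carbon gives a number 6 percentage points higher from compound 2 to compound 4 (within the scatter). Neither exchange therefore moves the read-out beyond the scatter in these pairs, and nothing available here bears on why that is so.

From the compounds shown here alone, whether a larger change on the same oxygen, such as an ethyl group or a longer chain, or a carboxylic acid or a primary amine on the aromatic carbon would give a step beyond the scatter remains open. With both steps within the scatter at this single concentration, the compounds shown also leave open whether either position influences cytotoxicity in these cells at all.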